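Ring-opened analogues in the trifluoromethylphenyl series

The source may hold more compounds than are shown below. What is called first, only, known or untested is meant among the compounds shown, and "the series" means these compounds.

Compound 1 `CCCN1C(=O)CCC1(O)c1cccc(C(F)(F)F)c1` and compound 2 `CCCCN1C(=O)CCC1(O)c1cccc(C(F)(F)F)c1` share a ring-containing core; compound 3 `CC(C)NC(=O)CCC(=O)c1cccc(C(F)(F)F)c1` and compound 4 `CCC(C)NC(=O)CCC(=O)c1cccc(C(F)(F)F)c1` share an open-chain core, and the difference between the two cores is not broken down here. In a functional assay on the whole organism with Mus musculus as the target (on this read-out lower numbers stand for an effect already at smaller amounts and higher numbers for an effect only at larger amounts of compound), compound 1 gives 150 mg/kg and compound 2 gives 183 mg/kg; the step of a 1.2-fold higher number from compound 1 to compound 2 (0.09 log units; within the scatter) corresponds to the change (methyl in place of hydrogen on a saturated chain carbon, three bonds along the chain from an amide-type nitrogen in a ring). For compound 3 only a limit is available in this assay, > 150 mg/kg, and the limit of > 150 mg/kg in this assay, at which 1 of the 3 values shown sits, marks it as such. The change from compound 3 to compound 4, (methyl in place of hydrogen on a saturated chain carbon, two bonds along the chain from an amide-type nitrogen), is the same kind of change as that from compound 1 to compound 2, but the place differs: two bonds along the chain from an amide-type nitrogen, rather than three bonds along the chain from an amide-type nitrogen in a ring. Because a 1.2-fold higher number from compound 1 to compound 2 (0.09 log units; within the scatter) is within the scatter, the step expected from compound 3 to compound 4 in this assay is small, a step that the limit leaves unreadable from compound 3 to compound 4. Since compound 3 stands only as a limit, the value expected for compound 4 is 200 mg/kg, within 100 mg/kg to 400 mg/kg, and a limit rather than a number is likely to be reported.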

Compound 4, dose for half-maximal effect: > 200 mg/kg
Compound 4: only a limit was reported; the forecaster's own chance of this, stated with the estimate: 60%; the middle value sits exactly at the limit.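

In this assay, going by these compounds alone, compound 3 and compound 4 are both reported only as limits, and no step between them can be read. The compounds shown leave open whether methyl in place of hydrogen, two bonds along the chain from an amide-type nitrogen, changes the read-out at all, and how the open-chain core compares with the core of compound 1.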